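The compounds below may be only part of what the source reports. "The series", "measured", "known", "first", "only" and "open" are said of these compounds alone.

Of the compounds shown here, three have been tested in a functional assay on 786-0 cells (Homo sapiens) for cytotoxicity, read by sulforhodamine B assay, with a stated time of 48 h (on this read-out lower numbers stand for stronger inhibition of growth and higher numbers for weaker inhibition of growth), all sharing a chlorinated bicyclic core carrying a benzyl group with a chloromethyl substituent. Compound 2, `ClCc1ccccc1Cn1cnc2c(Cl)ncnc21`, gives 17800 nM. Compound 1, `ClCc1ccccc1Cn1cnc2c(Cl)nc(Cl)nc21`, gives 1860 nM. The two differ by chloro in place of hydrogen on an aromatic carbon, and that change produced a 9.6-fold lower number from compound 2 to compound 1 (0.98 log units; beyond the scatter). Compound 3, `ClCc1cccc(Cn2cnc3c(Cl)ncnc32)c1`, gives 6160 nM; it has the same atoms as compound 2 joined differently, and the difference between the two cores is not broken down here. Compound 4, `ClCc1cccc(Cn2cnc3c(Cl)nc(Cl)nc32)c1`, has not been measured. It differs from compound 3 by chloro in place of hydrogen on an aromatic carbon, the same change seen from compound 2 to compound 1, at a place described in the same words. If compound 4 follows that earlier step, a similar drop is expected, about a 9.5-fold lower number from compound 3 to compound 4 (0.98 log units; beyond the scatter), because compound 3 starts from 6160 nM. Compound 4 is therefore estimated at 650 nM, likely between 250 nM and 1800 nM.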

Compound 4, concentration for 50% growth inhibition: 12300 nM
The estimate for compound 4 lay 19-fold (1.28 log units) below the measured number; measured number above the stated range.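

Read in this assay, chloro in place of hydrogen on an aromatic carbon of the second core gives a 2.0-fold higher number from compound 3 to compound 4 (0.30 log units; within the scatter), a step that cannot be told apart from no change. The gain seen on the first core therefore did not carry over to the second: the same change on two cores in this assay, a 9.6-fold lower number (0.98 log units; beyond the scatter) from compound 2 to compound 1 and a 2.0-fold higher number (0.30 log units; within the scatter) from compound 3 to compound 4, 19-fold (1.28 log units) apart, beyond the scatter of two such steps. This shows that, for these two cores, the step on one was a poor guide to the step on the other, but two pairs cannot show why they part or how the change would behave on a further core.

The compounds shown carry only chloro at this place. Going by these compounds, whether an amine, a methoxy group or a longer chain there would also behave differently on the two cores remains open.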